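The source may hold more compounds than are shown below. What is called first, only, known or untested is meant among the compounds shown, and "the series" means these compounds.

Three sulfonamides have been measured in an assay on isolated protein for inhibition of alkaline phosphatase, tissue-nonspecific isozyme (Homo sapiens); a higher number here means a weaker inhibitor, a lower number a stronger inhibitor. Compound 1 `COc1ccc(Cl)cc1S(=O)(=O)Nc1cncc(-c2ccc(C)cc2)c1` gives 147 nM, and compound 3 `COc1ccc(Cl)cc1S(=O)(=O)Nc1cncc(-c2ccc(Cl)cc2)c1` gives 198 nM. These two share a core, and the step of a 1.3-fold lower number from compound 3 to compound 1 (0.13 log units; within the scatter) comes from a single change: methyl in place of chloro on an aromatic carbon. Compound 2 `COc1cc(Cl)ccc1S(=O)(=O)Nc1cccnc1` is built on another core and gives 4170 nM in this assay; how the core of compound 2 differs from the core of compound 3 is not broken down here. Compound 4 `COc1cc(C)ccc1S(=O)(=O)Nc1cccnc1` has not yet been measured in this assay. It differs from compound 2 by methyl in place of chloro on an aromatic carbon. Going by the values given here, this is the same kind of change as the one from compound 3 to compound 1, not the same: in compound 2 and compound 4 the carbon carrying the group is meta to a methoxy group and para to a large group, whereas in compound 3 and compound 1 it is only para to a large group. Because the step of a 1.3-fold lower number from compound 3 to compound 1 (0.13 log units; within the scatter) stayed within the scatter, a small step is expected here too, a 1.1-fold lower number from compound 2 to compound 4 (0.04 log units; within the scatter). Compound 4 is therefore expected to give about 3800 nM in this assay, most likely between 1700 nM and 8500 nM.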

Compound 4, half-maximal inhibitory concentration: 896 nM
Beside the measured number, compound 4's estimate is 4.2-fold (0.63 log units) above it; the whole stated range lies above it.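

In this assay the change of chloro to methyl on an aromatic carbon gives a 4.7-fold lower number from compound 2 to compound 4 (0.67 log units; beyond the scatter), and the same change does not come out at one size on the two cores: the same change on two cores in this assay, a 1.3-fold lower number (0.13 log units; within the scatter) from compound 3 to compound 1 and a 4.7-fold lower number (0.67 log units; beyond the scatter) from compound 2 to compound 4, 3.5-fold (0.54 log units) apart, beyond the scatter of two such steps. This shows that, for these two pairs, the size of the step measured on one core could not be carried over to the other. It does not show which difference between the cores matters, since they differ in more than one way, among them that the carbon carrying the group is meta to a methoxy group only in compound 2 and compound 4, nor does it show how the step would run on any further core.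

At that carbon the compounds shown carry only chloro or methyl, which leaves open how an amine or a carboxylic acid there would fare on either core. Also open, from the compounds shown here alone, is whether the step seen on the core of compound 2 would hold for an ethyl group in place of the methyl.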